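Swapping the Nitrile for a Benzothiazole on the Shared Core

The compounds below may be only part of what the source reports. "The series", "measured", "known", "first", "only" and "open" are said of these compounds alone.

Compound 1 `N#Cc1cc(-c2ccccc2)c2ccc(OCc3cccc(C4(O)CCOCC4)c3)cc2c1`: 120 nM
Compound 2 `OC1(c2cccc(COc3ccc4c(-c5ccccc5)cc(-c5nn[nH]n5)cc4c3)c2)CCOCC1`: > 6000 nM, a limit of the assay rather than a number
Compound 3 `N#Cc1cc(-c2ccoc2)c2ccc(OCc3cccc(C4(O)CCOCC4)c3)cc2c1`: 30 nM

All three were tested in an assay on isolated protein with Polyunsaturated fatty acid 5-lipoxygenase (Homo sapiens) as the target; on this read-out lower numbers stand for stronger inhibition and higher numbers for weaker inhibition. Compound 3 gives the lowest of the two numbers shown, set apart from compound 1 by a 4.0-fold lower number from compound 1 to compound 3 (0.60 log units; beyond the scatter). Going by the values given here, for compound 2 only the limit of > 6000 nM in this assay, at which 1 of the 3 values shown sits, is known, so no step to it can be sized.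

Compound 4 `OC1(c2cccc(COc3ccc4c(-c5ccoc5)cc(-c5nc6ccccc6s5)cc4c3)c2)CCOCC1` differs from compound 3 by 1,3-benzothiazol-2-yl in place of cyano on an aromatic carbon. Among the compounds with values here, the one measured step at this position, an at least 50-fold higher number from compound 1 to compound 2 (1.69 log units; beyond the scatter), replaced the cyano with a different group and the number climbed past the assay limit. The step for compound 4 is therefore estimated as a 10-fold higher number from compound 3 to compound 4 (1.00 log units; beyond the scatter). Compound 4 is estimated at 300 nM, within 60 nM to 3000 nM.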

Compound 4, half-maximal inhibitory concentration: > 6000 nM
Compound 4 ended at the assay's limit (the forecaster's own chance of this, stated with the estimate: 10%); middle value at least 20-fold (1.30 log units) away from the limit.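

The change in an at least 200-fold higher number from compound 3 to compound 4 (2.30 log units; beyond the scatter) shows that the loss seen on replacing the nitrile is not confined to the phenyl compounds, as it also appears with furan-3-yl on the shared core. Compound 4 gives a limit of the assay and not a number: the limit of > 6000 nM in this assay, at which 2 of the 4 values shown sit. So neither replacement of the nitrile shown here, 2H-tetrazol-5-yl or 1,3-benzothiazol-2-yl, keeps a measurable value.

As far as these compounds go, whether a carboxylic acid, a primary amide or an amine at this position would keep the inhibition remains open.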